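Thienopyridine carboxamide series: benzyl to thiourea at the ring nitrogen

The source may hold more compounds than are shown below. What is called first, only, known or untested is meant among the compounds shown, and "the series" means these compounds.

Measured so far:
compound 1 `NC(=O)c1c(NC(=O)c2ccccc2Cl)sc2c1CCN(Cc1ccccc1)C2` in a functional assay on HL-60 cells (Homo sapiens) for antiproliferative activity, with a stated time of 24 h; a lower number here means a stronger inhibitor, a higher number a weaker inhibitor: 12000 nM
compound 2 `NC(=O)c1c(NC(=O)c2ccccc2F)sc2c1CCN(Cc1ccc(Cl)cc1Cl)C2` in this assay: 13100 nM

Both measured compounds share the carboxamide-bearing core and differ in the halogen on the benzamide and in the substitution of the benzyl group. Compound 1 gives the lower of the two numbers, but its gap to compound 2 lies within the scatter, so the two are indistinguishable on these data and neither can be called more or less potent.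

Compound 3 `NC(=O)c1c(NC(=O)c2ccccc2Cl)sc2c1CCN(C(=S)Nc1ccccc1Br)C2` has not yet been measured. Relative to compound 1 the change is a group of 10 heavy atoms (7 carbon, 1 nitrogen, 1 sulfur, 1 bromine; one six-membered aromatic ring of carbon only) in place of a group of 7 heavy atoms (7 carbon; one six-membered aromatic ring of carbon only), on an amine nitrogen in a ring. Among the measured compounds shown here, the data hold no step that isolates this change, and no comparison among the measured compounds speaks to the ring nitrogen substituent beyond the scatter. Without such a step, a change in this assay of no more than the scatter is expected, with the direction left open. The expected step from compound 1 to compound 3 is a 1.2-fold lower number from compound 1 to compound 3 (0.08 log units; within the scatter). Compound 3 is expected to give about 10000 nM, with a range from 3000 nM to 35000 nM.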

Compound 3, half-maximal inhibitory concentration: 9090 nM
Estimate against measurement, compound 3: 1.1-fold (0.04 log units) above; the range from low to high includes it.
By their numbers in this assay, from the lowest: compounds 3, 1 and 2 (each within the scatter of the next).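

With the rest of compound 1 held fixed, the exchange of benzyl for the thiourea group on the amine nitrogen in a ring gives a 1.3-fold lower number from compound 1 to compound 3 (0.12 log units; within the scatter) in this assay. Among the compounds shown here, this is the first comparison that isolates this position, and on these numbers the two groups cannot be told apart, even though the entering group adds a hydrogen-bond donor, a hydrogen-bond acceptor, a double bond outside aromatic rings and a bromine. No supporting evidence bears on this result.

The compounds shown do not separate the thiourea link from the bromine on its aromatic ring, so a urea with oxygen in place of sulfur, or the same thiourea with an unsubstituted phenyl ring, would be needed to tell these parts apart. Also open, from the compounds shown here alone, is whether any group at this nitrogen moves the number beyond the scatter, for example a free secondary amine, a small acetyl group or a longer alkyl chain, and the separate contributions of the two differences between compound 1 and compound 2 remain unresolved.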